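Replacing trifluoromethyl with isopropoxy in compound 3

A few compounds are considered here, and "the series" means these few. Any claim that something is new, unique, unknown or untested is made for them only; others in the source may bear on it.

Readings in a physicochemical assay for solubility, read by nephelometry, measured as kinetic solubility, at pH 6.5; a lower number here means a less soluble compound, a higher number a more soluble compound:
Compound 1 `CC(C)Oc1ccc(C(O)(c2ccc(Cl)cc2)c2cccnc2)cc1` gives 1.6 ug/mL as a number
Compound 2 `OC(c1ccc(Cl)cc1)(c1cccnc1)c1ccc(Cl)cc1F` gives 1.6 ug/mL as a number
Compound 3 `OC(c1ccc(C(F)(F)F)cc1)(c1cccnc1)c1ccc(Cl)cc1F` gives < 1.6 ug/mL as a limit

In this assay compound 3 stands at < 1.6 ug/mL as a limit and not a number. Compound 4 `CC(C)Oc1ccc(C(O)(c2cccnc2)c2ccc(Cl)cc2F)cc1` differs from it by isopropoxy in place of trifluoromethyl on an aromatic carbon in one change, isopropoxy in place of trifluoromethyl on an aromatic carbon. Going by the values given here, the one measured step at that place is a number no higher from compound 2 to compound 3 (the limit leaves the size open) and its size cannot be read. A rise beyond the scatter is not expected, because compound 1 gives 1.6 ug/mL while carrying isopropoxy. The estimated step is a number no lower from compound 3 to compound 4 (the limit leaves the size open) and it is expected to be small. Compound 4 is expected at 1.6 ug/mL within a range of 1 ug/mL to 4 ug/mL and may read only as a limit.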

Compound 4, solubility: 1.6 ug/mL
Beside the measured number, compound 4's estimate shows no gap at the digits printed, and the stated range covers the measured number.
By their numbers in this assay, from the lowest: compounds 1, 2 and 4 (each within the scatter of the next).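

In this assay, isopropoxy in place of chloro on this aromatic carbon gives no change at the digits printed from compound 2 to compound 4 (within the scatter), so the two groups cannot be told apart here, and fluoro in place of hydrogen on an aromatic carbon gives no change at the digits printed from compound 1 to compound 4 (within the scatter). Among the groups shown at this position, only trifluoromethyl, in compound 3, reads as a limit. Isopropoxy in place of trifluoromethyl on this aromatic carbon gives a number no lower from compound 3 to compound 4 (the limit leaves the size open). The steps involving compound 3 cannot be read, its reading being a limit and not a number: the limit of < 1.6 ug/mL in this assay, at which 1 of the 4 values shown sits.

As far as these compounds go, whether an amine or a carboxylic acid on this carbon would give a higher reading in this assay remains open, as does how far compound 3 truly lies from the others.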